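The compounds below may be only part of what the source reports. "The series", "measured", "known", "first", "only" and "open" are said of these compounds alone.

Series notes in an assay on isolated protein for inhibition of biotin--protein ligase (Homo sapiens), read by scintillation counting, with a stated time of 10 min; a lower number here means a stronger inhibitor, a higher number a weaker inhibitor. Compound 2 `COc1cccc(Cn2cc(CCCCC[C@@H]3SC[C@@H]4NC(=O)N[C@@H]43)nn2)c1` stands at a limit of the assay: in this assay compound 2 gives > 16000 nM, a limit rather than a number. Compound 1 `O=C1N[C@H]2[C@H](CS[C@H]2CCCCCc2cn(Cc3ccccc3O)nn2)N1` sits at the same limit, giving > 16000 nM in this assay. Compound 3 `O=C1N[C@H]2[C@H](CS[C@H]2CCCCCc2cn(Cc3ccc(C(F)(F)F)cc3)nn2)N1` likewise gives > 16000 nM in this assay, again a limit. All three measured values thus sit at the limit of > 16000 nM in this assay, at which 3 of the 3 values shown sit, and none of the steps among them can be read: a step that the two limits leave unreadable from compound 1 to compound 2, a step that the two limits leave unreadable from compound 1 to compound 3 and a step that the two limits leave unreadable from compound 2 to compound 3 are all of unreadable size.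

Compound 4 `O=C1N[C@H]2[C@H](CS[C@H]2CCCCCc2cn(Cc3ccccc3Cl)nn2)N1` is not yet measured in this assay. It differs from compound 2 as follows: 2-chlorophenyl in place of 3-methoxyphenyl on a saturated chain carbon bound to an aromatic nitrogen. The three measured steps, each exchanging one substituted phenyl for another on the saturated chain carbon bound to an aromatic nitrogen, bear on this change, and each was unreadable because both of its ends sit at the limit of > 16000 nM in this assay, at which 3 of the 3 values shown sit. Going by the values given here, no measured step shows such an exchange moving the value off this limit. The expected step is therefore a step that the limit leaves unreadable from compound 2 to compound 4, that is, no readable change. Compound 4 is estimated at 30000 nM, within 8000 nM to 120000 nM, and is expected most likely to be reported only as a limit.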

Compound 4, inhibition constant: > 16000 nM
Compound 4: no number, only a limit (the forecaster's own chance of this, stated with the estimate: 85%); the middle value does not contradict the limit.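

No new step can be read from compound 4 to compound 1, compound 2 or compound 3, because all four compounds give a limit rather than a number: the limit of > 16000 nM in this assay, at which 4 of the 4 values shown sit.

The compounds shown leave open whether any exchange of the substituted phenyl on a saturated chain carbon bound to an aromatic nitrogen moves the value in this assay off this limit.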